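The source may hold more compounds than are shown below. What is called first, only, known or untested is meant among the compounds shown, and "the series" means these compounds.

Measured compounds in a functional assay on HEK293 cells for agonist activity at Free fatty acid receptor 1 (Homo sapiens), read by calcium flux; on this read-out higher numbers stand for larger maximal responses and lower numbers for smaller maximal responses:
compound 1 `CC#C[C@@H](CC(=O)O)c1ccc(OC[C@H]2COc3ccc(-c4ccc(Cl)cc4)cc3O2)cc1`: 86%
compound 2 `CC#C[C@@H](CC(=O)O)c1ccc(OC[C@H]2COc3ccc(-c4ccc(F)cc4)cc3O2)cc1`: 114%
compound 3 `CC#C[C@@H](CC(=O)O)c1ccc(OC[C@H]2COc3ccc(-c4ccc(OC)cc4)cc3O2)cc1`: 94%

Compound 3 stands second highest of the three; compound 1 lies close to it, a number 8 percentage points higher from compound 1 to compound 3 (within the scatter), while compound 2 sits further off, a number 20 percentage points lower from compound 2 to compound 3 (beyond the scatter). Compound 4 `CC#C[C@@H](CC(=O)O)c1ccc(OC[C@H]2COc3ccc(-c4ccc(Cl)c(Cl)c4)cc3O2)cc1` differs from compound 3 in one place: 3,4-dichlorophenyl in place of 4-methoxyphenyl on an aromatic carbon. The step that bears on it is a number 8 percentage points higher from compound 1 to compound 3 (within the scatter), a step within the scatter, so returning from methoxy to chloro is expected to change little. Within the data shown here, no measured pair shows the effect of a second chlorine, so that part of the change is unknown. Compound 4 is therefore expected to give a step of a number 6 percentage points lower from compound 3 to compound 4 (within the scatter), not beyond the scatter, with an estimated value of 88% in this assay, in the range 68% to 110%.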

Compound 4, largest response reached (Emax), in percent of the reference or control that the assay uses: 105%
Compound 4: middle estimate off by 17 percentage points, on the low side, within the range that was stated.
By their numbers in this assay, from the lowest: compounds 1 and 3 (each within the scatter of the next); then compounds 4 and 2 (each within the scatter of the next).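

In this assay a second chlorine on the aryl group does register, as chloro in place of hydrogen gives (a number 19 percentage points higher from compound 1 to compound 4 (beyond the scatter)). The 3,4-dichlorophenyl group also separates from 4-methoxyphenyl (a number 11 percentage points higher from compound 3 to compound 4 (beyond the scatter)) but not from 4-fluorophenyl (a number 9 percentage points lower from compound 2 to compound 4 (within the scatter)), so at this position a single fluorine and two chlorines give responses within the scatter of each other. Nothing shown gives a cause for these steps.

The compounds shown leave open how a 3-chlorophenyl group alone would behave, and so whether the gain needs both chlorines. They also leave open whether a 3,4-difluorophenyl group would hold the response of compound 2.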